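From Amide to Ester on a Shared Core

A few compounds are considered here, and "the series" means these few. Any claim that something is new, unique, unknown or untested is made for them only; others in the source may bear on it.

Two measured compounds share one core. Compound 1 `COC(=O)c1ccc2c(c1)[n+]([O-])c(C(C)=O)c(C)[n+]2[O-]` was tested in an ADME assay on Vero cells (Chlorocebus sabaeus) for cytotoxicity, read by WST assay, with a stated time of 48 h; a higher number here means a weaker inhibitor, a lower number a stronger inhibitor. There compound 1 reaches only the limit > 100000 nM, which is a ceiling of the measurement rather than a number. Compound 2 `CCOC(=O)c1ccc2c(c1)[n+]([O-])c(C(N)=O)c(C)[n+]2[O-]` likewise gives in this assay only the limit > 100000 nM, again not a number. Within the data shown here, compound 2 thus stands where every value so far stands: both values shown sit at the limit of > 100000 nM in this assay, at which 2 of the 2 values shown sit. Compound 3 `CCOC(=O)c1ccc2c(c1)[n+]([O-])c(C(=O)OC)c(C)[n+]2[O-]` has not yet been measured and differs from compound 2 in one place: methoxy in place of amino on a carbonyl carbon. Among the measured compounds shown here, no measured step exists between any two compounds here, so no size of effect can be read from the data. Because compound 1 and compound 2 both sit at the limit of > 100000 nM in this assay, at which 2 of the 2 values shown sit, compound 3 is expected to show no step beyond the scatter, namely a number no higher from compound 2 to compound 3 (the limit leaves the size open). The estimate for compound 3 in this assay is 100000 nM, within 50000 nM to 200000 nM, most likely reported again as a limit.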

Compound 3, half-maximal inhibitory concentration: > 100000 nM
Compound 3: only a limit was reported; the forecaster's own chance of this, stated with the estimate: 85%; the middle value sits exactly at the limit.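

Among these compounds, compound 2 and compound 3 each give only a limit in this assay, not a number, and no step between them can be read. The compounds shown leave open what concentration, if any, would reach a measurable effect on these cells.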